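Swapping the ring on the chain: compound 3 to compound 4

A few compounds are considered here, and "the series" means these few. Any claim that something is new, unique, unknown or untested is made for them only; others in the source may bear on it.

Of the compounds shown here, three built on one shared core have been measured in a functional assay on HepG2 cells (Homo sapiens) for antiproliferative activity, read by MTT assay, with a stated time of 24 h; a higher number here means a weaker inhibitor, a lower number a stronger inhibitor. Compound 1 `COc1ccc(C(=O)/C=C/c2ccc(Br)cc2)c2c1C=CC(C)(C)O2` carries a 4-bromophenyl on a double-bonded chain carbon bound to a double-bonded chain carbon, and in this assay compound 1 gives > 10000 nM, which is a limit of the assay and not a number. Compound 2 `COc1ccc(C(=O)/C=C/c2ccco2)c2c1C=CC(C)(C)O2` carries a furan-2-yl at that place, and in this assay compound 2 gives > 10000 nM, again a limit. Compound 3 `COc1ccc(C(=O)/C=C/c2ccccn2)c2c1C=CC(C)(C)O2` carries a pyridin-2-yl there and is the only one of the three with a measured number, giving 5760 nM in this assay. The steps toward it are an at least 1.7-fold lower number from compound 1 to compound 3 (0.23 log units; that floor lies within the scatter) and an at least 1.7-fold lower number from compound 2 to compound 3 (0.23 log units; that floor lies within the scatter), both floors rather than full sizes because of the limit of > 10000 nM in this assay, at which 2 of the 3 values shown sit; the step that the two limits leave unreadable from compound 1 to compound 2 cannot be read at all.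

Compound 4 `COc1ccccc1/C=C/C(=O)c1ccc(OC)c2c1OC(C)(C)C=C2` differs from compound 3 by 2-methoxyphenyl in place of pyridin-2-yl on a double-bonded chain carbon bound to a double-bonded chain carbon. Among the measured compounds only compound 1 carries a carbon-only aromatic ring at that place, and it sits at the limit. A return to a carbon-only ring is therefore expected to push the number back upward, the expected step being a 1.6-fold higher number from compound 3 to compound 4 (0.19 log units; within the scatter), though its size is uncertain. Compound 4 is accordingly estimated at 9000 nM, with a range from 3500 nM to 25000 nM.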

Compound 4, half-maximal inhibitory concentration: > 10000 nM
Compound 4 ended at the assay's limit; the forecaster's own chance of this, stated with the estimate: 45%; at least 1.1-fold (0.04 log units) between middle value and limit.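

Among these compounds, with compound 4, the 2-methoxyphenyl joins the 4-bromophenyl and the furan-2-yl at the limit in this assay, so the pyridin-2-yl remains the only group at this place on the chain with a measured number. From the compounds shown here alone, replacing it with the 2-methoxyphenyl gives an at least 1.7-fold higher number from compound 3 to compound 4 (0.23 log units; that floor lies within the scatter), and this is a floor rather than a full size, so the true distance between the two groups remains unknown. The steps from compound 1 and from compound 2 to compound 4 cannot be read, and limits rather than numbers describe most of this small series: the limit of > 10000 nM in this assay, at which 3 of the 4 values shown sit.

The compounds shown leave open whether the number seen for compound 3, 5760 nM, depends on the ring nitrogen of the pyridin-2-yl or on that ring as a whole, a question that a pyridin-3-yl, a pyridin-4-yl or a pyrimidinyl at this place could address. They also leave open whether an aminophenyl, a carboxylic acid on the phenyl ring or a longer chain on the double-bonded chain carbon would give a number at all in this assay.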